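From 1-methyl-1H-pyrazol-4-yl to 3,5-difluorophenyl in a cell assay

A few compounds are considered here, and "the series" means these few. Any claim that something is new, unique, unknown or untested is made for them only; others in the source may bear on it.

Three compounds sharing one core have entries in a functional assay on EBC-1 cells (Homo sapiens) for antiproliferative activity, with a stated time of 72 h (a higher number here means a weaker inhibitor, a lower number a stronger inhibitor), but only one of them carries a number. Compound 1 `Cn1cc(-c2cc(C(F)(F)F)c3ncc(Cc4ccc5ncccc5c4)n3c2)cn1` has "not determined" (no result reported) as its entry. Compound 2 `Cn1cc(-c2cc(C#N)c3ncc(Cc4ccc5ncccc5c4)n3c2)cn1` also has "not determined" (no result reported) as its entry. Among the compounds with values here, compound 3 `Cn1cc(-c2cc(F)c3ncc(Cc4ccc5ncccc5c4)n3c2)cn1` gives 0.27 nM in this assay and this is the only measured value, so it cannot yet be ranked against a neighbour.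

The next compound to be tested is compound 4 `Fc1cc(F)cc(-c2cc(F)c3ncc(Cc4ccc5ncccc5c4)n3c2)c1` which keeps the shared core and changes one group. The change 3,5-difluorophenyl in place of 1-methyl-1H-pyrazol-4-yl on an aromatic carbon puts 3,5-difluorophenyl in place of 1-methyl-1H-pyrazol-4-yl on an aromatic carbon, meta to a fluoro group.

Within the data shown here, no measured pair shows how much such a swap matters, so any forecast rests on the change itself and on one starting point. With compound 3 at 0.27 nM as that starting point, an exchange of a whole ring has far more room to lose strength than to gain it. The expected result is a 110-fold higher number from compound 3 to compound 4 (2.05 log units; beyond the scatter) in the weaker direction, well beyond the usual scatter. For compound 4 the estimate is 30 nM with an expected range from 3 nM to 300 nM in this assay once it is measured.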

Compound 4, half-maximal inhibitory concentration: 790 nM
Compound 4: middle estimate off by 26-fold (1.42 log units), on the low side; measured number above the stated range.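

In this assay the exchange of 1-methyl-1H-pyrazol-4-yl for 3,5-difluorophenyl brings a 2900-fold higher number from compound 3 to compound 4 (3.47 log units; beyond the scatter) and so shows that this position, on an aromatic carbon meta to a fluoro group, is far from indifferent to the ring it carries. This first measured pair also shows that having an aromatic ring there is not enough to keep the strength of compound 3: the group that leaves is a five-membered aromatic ring with 2 nitrogen atoms and 2 hydrogen-bond acceptors, while the group that enters is a six-membered ring of carbon only with 2 fluorine atoms and 0 hydrogen-bond acceptors. These counts describe the change, but no measurement shown here identifies what caused the loss.

The pair cannot separate the effect of the ring nitrogens from that of the fluorines, since both differ at once. As far as these compounds go, a plain phenyl ring without fluorine, or a pyridin-4-yl group, at this position would help to tell these apart, and how much the result depends on the fluoro group elsewhere on the core also remains open.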